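Removing the chloro substituent from compound 2

The source may report more compounds than this note shows. Statements on the series, on what has been measured and on what is new or still open speak of the compounds shown alone.

Compound 2 `C[C@H](NCc1ccc(OCc2ccc(Cl)cc2)cc1)C(N)=O` is the stronger of the two measured compounds: in an assay on mitochondria for inhibition of Amine oxidase [flavin-containing] B (Rattus norvegicus) (a lower number here means a stronger inhibitor, a higher number a weaker inhibitor), compound 2 gives 2200 nM, while compound 1 `NC(=O)[C@@H](NCc1ccc(OCc2ccccc2)cc1)c1ccccc1` gives 73800 nM, a gap beyond the scatter. Compound 3 `C[C@H](NCc1ccc(OCc2ccccc2)cc1)C(N)=O` differs from compound 2 by hydrogen in place of chloro on an aromatic carbon, the carbon being para to a large group. Within the data shown here, no step between measured compounds covers this change, so the expectation rests only on compound 2 and its 2200 nM. A moderate weakening is expected, the step of a 3.6-fold higher number from compound 2 to compound 3 (0.56 log units; beyond the scatter) lying beyond the scatter. Compound 3 is estimated at 8000 nM, with a range from 2500 nM to 25000 nM.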

Compound 3, half-maximal inhibitory concentration: 260 nM
For compound 3 the middle estimate is 31-fold (1.49 log units) above the measured one, and the stated range ends above it.
By their numbers in this assay, from the lowest: compound 3; then compound 2; then compound 1.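

In this assay the change from 4-chlorophenyl to phenyl gives an 8.5-fold lower number from compound 2 to compound 3 (0.93 log units; beyond the scatter), so in this pair the chloro-bearing compound is the weaker inhibitor. The saturated chain carbon is also sensitive to substitution: with the phenyl end held constant, methyl in place of phenyl gives a 280-fold lower number from compound 1 to compound 3 (2.45 log units; beyond the scatter). No measurement shown here explains either step. Still open, going by these compounds, is how fluoro, methyl or methoxy on the same aromatic carbon would compare with hydrogen and chloro. Also open, on these data alone, is how hydrogen or ethyl would behave on the chain carbon.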